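Amino in place of phenyl on the five-membered ring

The compounds below may be only part of what the source reports. "The series", "measured", "known", "first", "only" and "open" are said of these compounds alone.

Measured so far:
compound 1, `Nc1nc(-c2ccc(Cl)cc2)nn1-c1ncnc2cc(Cl)ccc12`, in an assay on MCF7 cells for inhibition of Serine-protein kinase ATM (Homo sapiens), read by immunofluorescence, with a stated time of 1 h (a lower number here means a stronger inhibitor, a higher number a weaker inhibitor), compound 1 reports only a limit of the assay, > 40000 nM.
compound 2, `COc1cc2ncnc(-n3nc(-c4ccccc4)nc3N)c2cc1OC`, in this assay compound 2 gives 2000 nM.

For the measured compounds named here, compound 2 holds the only numerical value in this assay; the other entry, that of compound 1, is a limit and not a number, as noted in the limit of > 40000 nM in this assay, at which 1 of the 2 values shown sits. Going by the values given here, no pair of measured compounds differing in one place is available, so no measured step can be stated.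

Compound 3, `COc1cc2ncnc(-n3nc(N)nc3N)c2cc1OC`, differs from compound 2 in one place: amino in place of phenyl on an aromatic carbon. The phenyl that leaves is a six-carbon ring; what enters is a single nitrogen group. Among the compounds with values here, with no measured step to lean on, the expectation is a loss of inhibition beyond the usual scatter, because compound 2 at 2000 nM is itself only modestly active. For compound 3 the estimate is 12000 nM, within 3000 nM to 40000 nM. This estimate means a step of a 6.0-fold higher number from compound 2 to compound 3 (0.78 log units; beyond the scatter), expected to weaken inhibition, with a fair chance that the assay returns only a limit.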

Compound 3, half-maximal inhibitory concentration in the Serine-protein kinase ATM assay: > 40000 nM
Compound 3 gave a limit, no number; the forecaster's own chance of this, stated with the estimate: 30%; at least 3.3-fold (0.52 log units) between middle value and limit.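

For the compounds shown here, in the Serine-protein kinase ATM assay, amino in place of phenyl on the aromatic carbon of the five-membered ring gives an at least 20-fold higher number from compound 2 to compound 3 (1.30 log units; beyond the scatter), the first measured step, and it shows that inhibition at this position depends strongly on which group is present. The entry for compound 3, > 40000 nM, is a limit of the assay and not a number. In a physicochemical assay for solubility, in phosphate buffer, with a stated time of 18 h, at pH 7.4 (a higher number here means a more soluble compound, a lower number a less soluble compound), compound 2 gives 1000 nM and compound 3 gives 83000 nM. In the physicochemical assay the same change raises solubility, so the change that loses inhibition gains solubility: the measured solubility of compound 2, 1000 nM, and of compound 3, 83000 nM, an 83-fold higher number (1.92 log units; beyond the scatter)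

On these data alone, whether a pyridyl or a methyl group at this position would keep the inhibition of compound 2 while gaining part of the solubility of compound 3 remains open. As far as these compounds go, the full size of the loss of inhibition also remains open, since only a lower bound on the step can be read.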